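A Fused Amine Replaces the Phenylpiperidine of Compound 2

The source may hold more compounds than are shown below. What is called first, only, known or untested is meant among the compounds shown, and "the series" means these compounds.

Measured in a functional assay on A549 cells (Homo sapiens) for antiproliferative activity, read by MTT assay, with a stated time of 72 h; on this read-out higher numbers stand for weaker inhibition and lower numbers for stronger inhibition:
compound 1, `CCN(CC)CCCOc1cc2ncnc(Nc3ccc(C#N)cc3)c2cc1OC`, gives 50600 nM
compound 2, `COc1cc2c(Nc3ccc(C#N)cc3)ncnc2cc1OCCCN1CCC(c2ccccc2)CC1`, gives 9500 nM

Among the compounds with values here, of the two numbers in this assay, compound 2 holds the lower one; the only other compound, compound 1, sits a 5.3-fold lower number from compound 1 to compound 2 (0.73 log units; beyond the scatter) away, a step that came from placing 4-phenylpiperidin-1-yl in place of diethylamino on a saturated chain carbon, three bonds along the chain from an oxygen on an aromatic ring.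

Compound 3, `COc1cc2c(Nc3ccc(C#N)cc3)ncnc2cc1OCCCN1CCc2ccccc2C1`, changes the same position once more: 1,2,3,4-tetrahydroisoquinolin-2-yl in place of 4-phenylpiperidin-1-yl on a saturated chain carbon, three bonds along the chain from an oxygen on an aromatic ring. Within the data shown here, the one measured step, a 5.3-fold lower number from compound 1 to compound 2 (0.73 log units; beyond the scatter), concerns that same chain end and shows that the amine there can move the number markedly. The present change is smaller in kind, since a six-membered aromatic ring of carbon only stays in place and only its attachment to the ring bearing the nitrogen differs, so no step beyond the scatter is expected in this assay. Compound 3 is therefore estimated at 8500 nM, between 3000 nM and 25000 nM, a step of a 1.1-fold lower number from compound 2 to compound 3 (0.05 log units; within the scatter).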

Compound 3, half-maximal inhibitory concentration: > 100000 nM
Compound 3 gave a limit, no number (the forecaster's own chance of this, stated with the estimate: 3%); middle value at least 11-fold (1.07 log units) away from the limit.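

Read in this assay the exchange of 4-phenylpiperidin-1-yl for 1,2,3,4-tetrahydroisoquinolin-2-yl is a large loss (an at least 10-fold higher number from compound 2 to compound 3 (1.02 log units; beyond the scatter)), even though both groups hold the same kinds of ring, one six-membered non-aromatic ring with 1 hetero atom and one six-membered aromatic ring of carbon only. Within the data shown here, the chain end therefore responds not just to which rings the amine carries but to how they are joined, something the single earlier step could not show, while the comparison with the diethylamino group of compound 1 settles no order (an at least 1.9-fold higher number from compound 1 to compound 3 (0.29 log units; that floor lies within the scatter)). Compound 3 gave a limit and not a number: the limit of > 100000 nM in this assay, at which 1 of the 3 values shown sits.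

How far compound 3 really lies from compound 1 and compound 2 stays open, and the compounds shown offer no measured basis for saying why the two ring arrangements part so sharply. Also open, from the compounds shown here alone, is how a 4-benzylpiperidine, a morpholine or a shorter chain on the same core would read in this assay and whether the contrast seen here would hold for them.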